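Methoxy in place of chloro on the distal ring

The source may hold more compounds than are shown below. What is called first, only, known or untested is meant among the compounds shown, and "the series" means these compounds.

Of the compounds shown here, two have been measured in a functional assay on OVCAR-8 cells (Homo sapiens) for inhibition, read by sulforhodamine B assay, with a stated time of 48 h; on this read-out higher numbers stand for weaker inhibition of growth and lower numbers for stronger inhibition of growth. Compound 1 `N=C(N)c1ccc(-c2ccc(-c3cc(Cl)cc(Cl)c3)s2)cc1` gives 2420 nM there. Compound 2 `N=C(N)c1ccc(-c2ccc(-c3ccc(Cl)cc3)s2)cc1F` gives 983 nM in this assay, the lowest of the two numbers; the gap to compound 1 lies beyond the usual scatter of the method. Compound 3 `COc1ccc(-c2ccc(-c3ccc(C(=N)N)c(F)c3)s2)cc1` is the next compound, not yet measured in this assay. It differs from compound 2 by a single change: methoxy in place of chloro on an aromatic carbon. Within the data shown here, no measured pair in this set shows this change, so no step can be read from the numbers; the two values at hand fix only where compound 2 sits. The expected step is a 1.5-fold higher number from compound 2 to compound 3 (0.18 log units; within the scatter) in this assay, at most a mild weakening of growth inhibition, not clearly beyond the scatter. Compound 3 is therefore expected to give about 1500 nM in this assay, within a range from 500 nM to 4500 nM.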

Compound 3, concentration for 50% growth inhibition: 8220 nM
Beside the measured number, compound 3's estimate is 5.5-fold (0.74 log units) below it; the whole stated range lies below it.
By their numbers in this assay, from the lowest: compound 2; then compound 1; then compound 3.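

In this assay, methoxy in place of chloro on an aromatic carbon, para to a large group, gives an 8.4-fold higher number from compound 2 to compound 3 (0.92 log units; beyond the scatter), a loss of growth inhibition beyond the scatter. Among these compounds, this is the first step that can be read at this position, and it shows that the position does not tolerate every small group equally: the exchange of one group for another here is enough to move the number clearly. Nothing available explains the size of this step.

The compounds shown leave open whether the loss follows the oxygen link of methoxy or extends to other replacements for chloro, such as methyl, hydroxy, an amine or a longer ether like ethoxy. They also leave open whether the same exchange has a step of similar size on a core lacking the fluoro.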